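A few compounds are considered here, and "the series" means these few. Any claim that something is new, unique, unknown or untested is made for them only; others in the source may bear on it.

Working notes on the series. In a functional assay on MCF7 cells (Homo sapiens) for antiproliferative activity, read by MTT assay, with a stated time of 48 h (on this read-out higher numbers stand for weaker inhibition and lower numbers for stronger inhibition), compound 1 `Cc1ccc(-c2cc(NC(=O)/C=C/c3ccc(Cl)cc3)n[nH]2)cc1` gives 1190 nM, the highest of the three numbers in hand, though neither neighbour is separated from it beyond the scatter: compound 3 `O=C(/C=C/c1ccc(Cl)cc1)Nc1cc(-c2ccccc2)[nH]n1` gives 970 nM and compound 2 `COc1ccc(/C=C/C(=O)Nc2cc(-c3ccc(Br)cc3)[nH]n2)cc1` gives 590 nM. For the measured compounds named here, the only single-place step recorded, a 1.2-fold lower number from compound 1 to compound 3 (0.09 log units; within the scatter), concerns the aryl ring on the core and stays within the scatter. Compound 4 `Cc1ccc(-c2cc(NC(=O)/C=C/c3ccc(C(F)(F)F)cc3)n[nH]2)cc1` differs from compound 1 on the other ring: trifluoromethyl in place of chloro on an aromatic carbon, para to a large group. Going by the values given here, no measured step touches that ring, so there is nothing to anchor a shift in either direction; the expectation is a step within the scatter, a 1.1-fold lower number from compound 1 to compound 4 (0.03 log units; within the scatter). Compound 4 is expected to give 1100 nM, between 450 nM and 2800 nM.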

Compound 4, half-maximal inhibitory concentration: 720 nM
Estimate against measurement, compound 4: 1.5-fold (0.18 log units) above; measured number inside the range.
By their numbers in this assay, from the lowest: compounds 2, 4, 3 and 1 (each within the scatter of the next).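

In this assay, for the compounds shown here, trifluoromethyl in place of chloro on this ring gives a 1.7-fold lower number from compound 1 to compound 4 (0.22 log units; within the scatter), the first measured step at this position. Four heavy atoms in place of one thus leave the two numbers indistinguishable, so this position accepts the larger group without a change beyond the scatter. No measurement available here speaks to the reason for this result.

Still open, from the compounds shown here alone, is whether any group at this place moves the number beyond the scatter. An amine or a carboxylic acid there would test this.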